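The source may hold more compounds than are shown below. What is called first, only, known or untested is meant among the compounds shown, and "the series" means these compounds.

Measured in a functional assay on A549 cells (Homo sapiens) for antiproliferative activity, read by MTT assay, with a stated time of 48 h; on this read-out higher numbers stand for weaker inhibition and lower numbers for stronger inhibition:

- Compound 1 `COc1ccc(-c2nc3cccc(-c4cc(OC)c(OC)c(OC)c4)c3o2)cc1F`: 1800 nM
- Compound 2 `COc1cc(-c2cccc3nc(-c4ccc(Br)cc4)oc23)cc(OC)c1OC`: > 25000 nM (a limit of the assay, not a number)
- Compound 3 `COc1cc(-c2cccc3nc(-c4cccc(O)c4)oc23)cc(OC)c1OC`: 2000 nM

Compound 3 gives 2000 nM. It has one close neighbour on these numbers: a 1.1-fold higher number from compound 1 to compound 3 (0.05 log units; within the scatter). The only other result is a limit, as the limit of > 25000 nM in this assay, at which 1 of the 3 values shown sits, shows.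

Compound 4 `COc1cc(-c2cccc3nc(-c4ccco4)oc23)cc(OC)c1OC` has furan-2-yl in place of 3-hydroxyphenyl, on an aromatic carbon of a five-membered aromatic ring with 1 nitrogen and 1 oxygen, part of a fused or bridged system of two rings: furan-2-yl in place of 3-hydroxyphenyl on an aromatic carbon.

All three measured steps change the group at this same place, so all three bear on the question. Two of them are large: an at least 13-fold higher number from compound 1 to compound 2 (1.14 log units; beyond the scatter), and an at least 12-fold lower number from compound 2 to compound 3 (1.09 log units; beyond the scatter). The third shows that two different groups here can give matching results. Furan-2-yl itself has not been tested on this core, so the measured steps allow either outcome. The loss seen with compound 2, an at least 12-fold lower number from compound 2 to compound 3 (1.09 log units; beyond the scatter), tilts the expectation towards a higher number in this assay, though a moderate one. The estimated step is a 2.3-fold higher number from compound 3 to compound 4 (0.35 log units; beyond the scatter). Compound 4 is expected at 4500 nM, with an estimated range from 1500 nM to 15000 nM.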

Compound 4, half-maximal inhibitory concentration: 10300 nM
Beside the measured number, compound 4's estimate is 2.3-fold (0.36 log units) below it; the range from low to high includes it.
By their numbers in this assay, from the lowest: compounds 1 and 3 (each within the scatter of the next); then compound 4. At a limit, above all of these: compound 2.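

In this assay, the earlier groups at this place were all substituted phenyl rings, and furan-2-yl adds a five-membered aromatic ring with 1 hetero atom, which costs activity against both of the best results: a 5.2-fold higher number from compound 3 to compound 4 (0.71 log units; beyond the scatter), and a 5.7-fold higher number from compound 1 to compound 4 (0.76 log units; beyond the scatter). So the match between 3-hydroxyphenyl and 3-fluoro-4-methoxyphenyl does not extend to every aromatic group here, and this place proves to hold at least three levels of result rather than the two seen before. Compound 4 still ranks ahead of compound 2, an at least 2.4-fold lower number from compound 2 to compound 4 (0.38 log units; beyond the scatter), but that step rests on a limit and not a number: the limit of > 25000 nM in this assay, at which 1 of the 4 values shown sits.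

What the compounds shown leave open is whether the rise with furan-2-yl goes with the smaller ring, with its ring oxygen, or with the absence of any substituent on the ring, since all three change together in this one group. A thiophen-2-yl group, an unsubstituted phenyl or a 3-aminophenyl group at this place would be needed to pull these apart.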